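The source may hold more compounds than are shown below. What is called first, only, known or untested is meant among the compounds shown, and "the series" means these compounds.

Compound 1, `COc1ccc(OCC(=O)Nc2cccc(NC(=O)c3ccc(N(C)C)cc3)c2)cc1F`: 652 nM
Compound 2, `CCc1ccc(C(=O)Nc2cccc(NC(=O)COc3ccc4c(=O)ccoc4c3)c2)cc1`: 24 nM

In an assay on isolated protein for inhibition of Rho-associated protein kinase 2 (Homo sapiens), read by scintillation counting, radiometric assay and 33P incorporation, with a stated time of 40 min, in the presence of a further agent that is not named here (on this read-out higher numbers stand for weaker inhibition and lower numbers for stronger inhibition), compound 2 holds the lower of the two numbers; the gap from compound 1 to compound 2 lies well beyond the scatter. Compound 3, `N#Cc1ccc(C(=O)Nc2cccc(NC(=O)COc3ccc4c(=O)ccoc4c3)c2)cc1`, keeps the core of compound 2 and differs from it by cyano in place of ethyl on an aromatic carbon. Among the compounds with values here, no pair of measured compounds isolates this change, so there is no measured step to lean on. The step of a 1.7-fold higher number from compound 2 to compound 3 (0.22 log units; within the scatter) is expected to be small, a mild weakening if anything. Compound 3 is estimated at 40 nM, with a range from 10 nM to 160 nM.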

Compound 3, half-maximal inhibitory concentration: 15 nM
Estimate against measurement, compound 3: 2.7-fold (0.43 log units) above, and the stated range covers the measured number.
By their numbers in this assay, from the lowest: compounds 3 and 2 (each within the scatter of the next); then compound 1.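

In this assay, within the data shown here, 4-cyanophenyl in place of 4-ethylphenyl gives a 1.6-fold lower number from compound 2 to compound 3 (0.20 log units; within the scatter) and so marks the first measured single change at this position, para to a large group. Cyano adds a triple bond and a hydrogen-bond acceptor, yet the two numbers cannot be told apart in this assay. The data available offer no measured explanation for this result. Still open, going by these compounds, is how a carboxylic acid or a longer chain, such as butyl, would read at this same position on the shared core.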